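This account rests on a few compounds, and the source may have more. Where it says the series, first, only, none or still open, it means among the compounds named here.

In a functional assay on MDA-MB-231 cells (Homo sapiens) for antiproliferative activity, read by MTT assay, with stated times of 72 h and 4 h (on this read-out lower numbers stand for stronger inhibition and higher numbers for weaker inhibition), compound 2 `O=C(Nc1ccc(Cl)c(-c2nnc3c(Cl)cccn23)c1)c1cccc(Cl)c1` gives 66100 nM. Among the measured compounds shown here, its only measured neighbour is compound 1 `O=C(Nc1ccc(Cl)c(-c2nnc3c(Cl)cccn23)c1)c1ccccn1`, which in this assay gives 92000 nM; the step of a 1.4-fold lower number from compound 1 to compound 2 (0.14 log units; within the scatter) swapped the group on the carbonyl carbon and made no difference beyond the scatter. Compound 3 `CS(=O)(=O)c1ccc(C(=O)Nc2ccc(Cl)c(-c3nnc4c(Cl)cccn34)c2)cc1` alters the same place: 4-(methylsulfonyl)phenyl in place of 3-chlorophenyl on a carbonyl carbon. Because a 1.4-fold lower number from compound 1 to compound 2 (0.14 log units; within the scatter) stayed within the scatter when this carbonyl-bound group was exchanged, compound 3 is expected to show no step beyond the scatter, a 1.1-fold higher number from compound 2 to compound 3 (0.02 log units; within the scatter). The estimate for compound 3 is therefore 70000 nM, with a range from 25000 nM to 200000 nM.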

Compound 3, half-maximal inhibitory concentration: > 100000 nM
Compound 3 ended at the assay's limit; the forecaster's own chance of this, stated with the estimate: 15%; middle value at least 1.4-fold (0.15 log units) away from the limit.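

Compound 3 stands at a limit of this assay, not at a number. That leaves only floors, an at least 1.5-fold higher number from compound 2 to compound 3 (0.17 log units; that floor lies within the scatter) and an at least 1.0-fold higher number from compound 1 to compound 3 (0.03 log units; that floor lies within the scatter), so this position has still shown no change beyond the scatter, while a larger step to compound 3 remains possible. The top of the measurable range now comes into play: the limit of > 100000 nM in this assay, at which 1 of the 3 values shown sits.

All three compounds carry a six-membered aromatic ring on this carbonyl carbon. As far as these compounds go, what an amine or a short alkyl chain would do there stays open, as does any change to the shared core.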